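Urea series: expectation for the dimethylphenyl analogue

This account rests on a few compounds, and the source may have more. Where it says the series, first, only, none or still open, it means among the compounds named here.

Measured so far:
compound 1 `COc1cc(Nc2cc(NC(=O)Nc3c(Cl)cccc3Cl)ncn2)cc(C(F)(F)F)c1`: 33.1%
compound 2 `COc1cc(NC(=O)Nc2cc(Nc3ccc(OC)c(I)c3)ncn2)cc(OC)c1`: 40.1%
compound 3 `COc1cc(NC(=O)Nc2cc(Nc3cc(C(F)(F)F)ccc3OC)ncn2)cc(OC)c1`: 60%

In a functional assay on NCI-H226 cells (Homo sapiens) for inhibition, read by MTT assay, with a stated time of 48 h, tested at 10 uM (on this read-out higher numbers stand for more inhibition at the one concentration tested (going by the name of the read-out) and lower numbers for less inhibition), compound 2 gives 40.1%, the second highest of the three numbers. The nearest number is that of compound 1, which gives 33.1% in this assay, a result that lies within the scatter of compound 2; the two cannot be ordered. Compound 3 gives 60% in this assay, and this lies beyond the scatter above compound 2. No two of the measured compounds differ in a single place, so no single-change step can be read from the measured set, and the three structures differ in several places at once.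

Compound 4 `COc1cc(NC(=O)Nc2cc(Nc3ccc(C)c(C)c3)ncn2)cc(OC)c1` has not yet been measured in this assay. It differs from compound 2 by one change: 3,4-dimethylphenyl in place of 3-iodo-4-methoxyphenyl on a nitrogen on an aromatic ring

Among the compounds with values here, with no measured step of this kind to lean on, the expectation rests on compound 2 alone. The expected step of a number 2.1 percentage points lower from compound 2 to compound 4 (within the scatter) is taken to lie within the scatter, with no clear direction. In this assay compound 4 is therefore estimated at 38%, with a range from 22% to 55%.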

Compound 4, a percentage reported as inhibition, at one concentration (the size of the read-out at that concentration, not a potency): 45.3%
Beside the measured number, compound 4's estimate is 7.3 percentage points below it, within the range that was stated.
By their numbers in this assay, from the lowest: compounds 1, 2 and 4 (each within the scatter of the next, the first and the last beyond it); then compound 3.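

In this assay, the series now has its first single-change step, a number 5.2 percentage points higher from compound 2 to compound 4 (within the scatter), and on that step compound 2 and compound 4 cannot be ordered. At this place, on a nitrogen on an aromatic ring, 3,4-dimethylphenyl thus stands in for 3-iodo-4-methoxyphenyl without a separable difference in the read-out, even though the iodine, the oxygen and the one hydrogen-bond acceptor of the leaving group are gone from the entering group. This is one pair at a single concentration, so it describes the size of the read-out for these two compounds and not a potency, and nothing available explains the result.

From the compounds shown here alone, it remains open whether the same place would accept a phenyl ring carrying a morpholine, a carboxylic acid or a longer alkyl chain with a similarly small step. Within the data shown here, it also remains open whether the step from 3-iodo-4-methoxyphenyl to 3,4-dimethylphenyl stays this small when the group on the far side of the urea is something other than the one shared by compound 2 and compound 4.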